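The source may report more compounds than this note shows. Statements on the series, on what has been measured and on what is new or still open speak of the compounds shown alone.

In a functional assay on A549 cells (Homo sapiens) for cytotoxicity, read by MTT assay, with a stated time of 72 h (a higher number here means a weaker inhibitor, a lower number a stronger inhibitor), compound 1 (`O=C1c2c[n+]([O-])c3ccccc3c2C(=O)c2c1c1ccccc1n2CCCCN1CCNCC1`) gives 540 nM and compound 2 (`O=C1c2c[n+]([O-])c3ccccc3c2C(=O)c2c1c1ccccc1n2CCCCN1CCCCC1`) gives 150 nM, so compound 2 holds the lower of the two numbers. Compound 3 (`CCCN1CCN(CCCCn2c3c(c4ccccc42)C(=O)c2c[n+]([O-])c4ccccc4c2C3=O)CC1`) is not yet measured. Its difference from compound 2 is 4-propylpiperazin-1-yl in place of piperidin-1-yl on a saturated chain carbon, four bonds along the chain from an aromatic nitrogen.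

For the measured compounds named here, only one measured step bears on this: a 3.6-fold lower number from compound 1 to compound 2 (0.56 log units; beyond the scatter), a modest change at the same place, with piperidin-1-yl in place of piperazin-1-yl. Going by the values given here, compound 3 carries a piperazin-1-yl ring again, but with a propyl group that no measured compound has, so that step is only a partial guide. A modest rise in the number is expected in this assay, no larger than that measured step. The expected change is a 2.0-fold higher number from compound 2 to compound 3 (0.30 log units; within the scatter). For compound 3 the estimated value is 300 nM, with an expected range of 110 nM to 800 nM.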

Compound 3, half-maximal inhibitory concentration: 320 nM
Estimate against measurement, compound 3: 1.1-fold (0.03 log units) below; low and high end bracket the measured number.
By their numbers in this assay, from the lowest: compound 2; then compounds 3 and 1 (each within the scatter of the next).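

In this assay, the place on a saturated chain carbon, four bonds along the chain from an aromatic nitrogen, now has a third amine ring, and 4-propylpiperazin-1-yl in place of piperidin-1-yl gives a 2.1-fold higher number from compound 2 to compound 3 (0.33 log units; beyond the scatter). Compound 2, with piperidin-1-yl, therefore holds the lowest number against both piperazine-bearing compounds, with each step beyond the scatter. Propyl in place of hydrogen on the ring amine nitrogen is a new change and gives a 1.7-fold lower number from compound 1 to compound 3 (0.23 log units; within the scatter), so this substitution shows no separation between the two compounds in this assay.

No measurement offered here accounts for either step.

Still open, going by these compounds, is how a morpholine ring or a dimethylamino group would compare at this place. Also open is whether a shorter or longer chain would preserve the order among these three amine rings.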